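A few compounds are considered here, and "the series" means these few. Any claim that something is new, unique, unknown or untested is made for them only; others in the source may bear on it.

Compound 2 `COCCn1c(=O)c2c(nc(Cc3ccccc3)n2C)n(Cc2ccco2)c1=O` gives 174 nM in an assay on cell membranes for displacement of a labelled ligand from adenosine receptor A1 (Rattus norvegicus) (on this read-out higher numbers stand for weaker inhibition and lower numbers for stronger inhibition), the highest of the two numbers recorded, yet within the scatter of the other. Compound 1 `C=CCn1c(=O)c2c(nc(Cc3c(F)cccc3F)n2C)n(Cc2ccco2)c1=O` gives 132 nM in this assay. Compound 3 `COCCn1c(=O)c2c(nc(Cc3c(F)cccc3F)n2C)n(Cc2ccco2)c1=O` carries 2,6-difluorophenyl in place of phenyl on a saturated chain carbon bound to an aromatic carbon, and its result in this assay is not yet known. A small step is expected, because compound 1 gives 132 nM while carrying the same difluoro group on its own chain. The step from compound 2 to compound 3 is expected to be a 1.3-fold lower number from compound 2 to compound 3 (0.13 log units; within the scatter), inside the scatter. Compound 3 is expected to give about 130 nM, between 50 nM and 350 nM.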

Compound 3, inhibition constant: 195 nM
Compound 3: the middle estimate sits 1.5-fold (0.18 log units) below what was measured, and the stated range covers the measured number.
By their numbers in this assay, from the lowest: compounds 1, 2 and 3 (each within the scatter of the next).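

In this assay, 2,6-difluorophenyl in place of phenyl on a saturated chain carbon bound to an aromatic carbon gives a 1.1-fold higher number from compound 2 to compound 3 (0.05 log units; within the scatter), a step within the scatter, so this exchange has no readable effect here. Methoxymethyl in place of vinyl on a saturated chain carbon bound to an aromatic nitrogen gives a 1.5-fold higher number from compound 1 to compound 3 (0.17 log units; within the scatter), also within the scatter. No measurement shown offers an explanation for either result. Still open, going by these compounds, is whether an amine or a carboxylic acid in place of 2,6-difluorophenyl, or a longer chain in place of methoxymethyl, would produce a step beyond the scatter.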